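The source may report more compounds than this note shows. Statements on the series, on what has been measured and on what is new or still open speak of the compounds shown alone.

Compound 1 `O=C(CSc1nnc(COc2ccc3c(c2)CCCC3)o1)Nc1nc2ccccc2s1`, compound 2 `O=C(CSc1nnc(COc2ccc3c(c2)CCCC3)o1)Nc1nc2ccc(F)cc2s1` and compound 3 `COc1ccc2nc(NC(=O)CSc3nnc(COc4ccc5c(c4)CCCC5)o3)sc2c1` share one core and differ only on its outer ring. In a functional assay on A549 cells (Homo sapiens) for cytotoxicity, read by MTT assay, with a stated time of 24 h (on this read-out higher numbers stand for weaker inhibition and lower numbers for stronger inhibition), compound 1 gives 247000 nM, compound 2 gives 91700 nM and compound 3 gives 39300 nM, so compound 2 stands second highest of the three, with steps a 2.7-fold lower number from compound 1 to compound 2 (0.43 log units; beyond the scatter) and a 2.3-fold lower number from compound 2 to compound 3 (0.37 log units; beyond the scatter) around it. Compound 4 `O=C(CSc1nnc(COc2ccc3c(c2)CCCC3)o1)Nc1ncc([N+](=O)[O-])s1` changes something else: 5-nitro-1,3-thiazol-2-yl in place of 6-fluoro-1,3-benzothiazol-2-yl on an amide-type nitrogen. Going by the values given here, no measured step exchanges this ring, so the steps seen only show that changes here shift the number modestly. A modest move downward is therefore expected, a 1.8-fold lower number from compound 2 to compound 4 (0.26 log units; within the scatter), and compound 4 is estimated at 50000 nM, within 15000 nM to 200000 nM.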

Compound 4, half-maximal inhibitory concentration: 115000 nM
Beside the measured number, compound 4's estimate is 2.3-fold (0.36 log units) below it; measured number inside the range.
By their numbers in this assay, from the lowest: compound 3; then compounds 2 and 4 (each within the scatter of the next); then compound 1.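

Replacing 6-fluoro-1,3-benzothiazol-2-yl on the amide-type nitrogen with 5-nitro-1,3-thiazol-2-yl, a group of one ring instead of two, gives no real shift (a 1.3-fold higher number from compound 2 to compound 4 (0.10 log units; within the scatter)). Set against the other two-ring groups, the same group falls on both sides (a 2.9-fold higher number from compound 3 to compound 4 (0.47 log units; beyond the scatter)) and (a 2.1-fold lower number from compound 1 to compound 4 (0.33 log units; beyond the scatter)), so at this position one ring carrying a nitro group can match two rings. Nothing measured here gives a cause for these shifts. On these data alone, what a plain 1,3-thiazol-2-yl, or one bearing an amine where the nitro stands, would give remains open, so the share of the nitro group in these numbers cannot be told.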